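Carbamoyl in place of hydroxymethyl on compound 2

The source may report more compounds than this note shows. Statements on the series, on what has been measured and on what is new or still open speak of the compounds shown alone.

Going by the values given here, compound 2 `Cc1ccc2ccc(-c3cccc(CO)c3)cc2n1` gives 8700 nM in a functional assay on CHO cells for inhibition of metabotropic glutamate receptor 5 (Rattus norvegicus), read by FLIPR and calcium flux (on this read-out higher numbers stand for weaker inhibition and lower numbers for stronger inhibition), the second highest of the three numbers so far. Compound 1 `Cc1ccc2ccc(-c3cccnc3)cc2n1` gives 510 nM and compound 3 `Cc1ccc2ccc(-c3cccc(O)c3)cc2n1` gives 19000 nM. Among the compounds with values here, the one measured step at this position is a 2.2-fold higher number from compound 2 to compound 3 (0.34 log units; beyond the scatter). Compound 4 `Cc1ccc2ccc(-c3cccc(C(N)=O)c3)cc2n1` carries the change (carbamoyl in place of hydroxymethyl on an aromatic carbon); the change keeps one hydrogen-bond donor and one acceptor. Within the data shown here, no measured step covers carbamoyl, so the hydroxy step is the nearest guide and it was modest. A step of similar or smaller size is expected, in either direction or none beyond the scatter, a 1.0-fold higher number from compound 2 to compound 4 (0.01 log units; within the scatter). Compound 4 is therefore estimated at 9000 nM in this assay, with a range from 3000 nM to 30000 nM.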

Compound 4, half-maximal inhibitory concentration: > 10000 nM
Compound 4 ended at the assay's limit; the forecaster's own chance of this, stated with the estimate: 10%; middle value at least 1.1-fold (0.04 log units) from the limit.
By their numbers in this assay, from the lowest: compound 1; then compound 2; then compound 3.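

In this assay compound 4 gives > 10000 nM, which is a limit of the assay and not a number. Carbamoyl in place of hydroxymethyl gives an at least 1.1-fold higher number from compound 2 to compound 4 (0.06 log units; that floor lies within the scatter), and the step between compound 3 and compound 4 cannot be read. With both replacements of hydroxymethyl now shown, neither gives a lower number than compound 2, so this position has yet to show a gain. On these data alone, how far compound 4 lies past its limit stays open, as does whether an aminomethyl group or a carboxylic acid here would give a lower number than compound 2.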